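The source may report more compounds than this note shows. Statements on the series, on what has been measured and on what is new or still open speak of the compounds shown alone.

Working notes on the series. Compound 1 `C=C1C[C@]23C[C@@]1(O)CC[C@H]2[C@@]12C=C[C@H](O)[C@@](C)(C(=O)O1)[C@H]2[C@@H]3C(=O)OC` has been run in a functional assay on SUD4 cells (Homo sapiens) for cytotoxicity, read by luminescence and CellTiter-Glo, with a stated time of 24 h; on this read-out higher numbers stand for weaker inhibition and lower numbers for stronger inhibition. In this assay compound 1 gives > 10000 nM, a limit of the assay rather than a number. Compound 2 `COC(=O)/C=C/Oc1ccc2c(c1C)[C@H](C(=O)OC)[C@@]13CC(=O)[C@@](C)(CC[C@@H]21)C3` in this assay gives > 10000 nM, again a limit. Compound 3 `C=C1C[C@]23C[C@@]1(O)CC[C@H]2c1cc2c(C(=O)OC)coc2c(C)c1[C@@H]3C(=O)OC` in this assay gives > 10000 nM, also a limit. For the measured compounds named here, compound 1 therefore cannot be placed among the values shown: the limit of > 10000 nM in this assay, at which 3 of the 3 values shown sit, no compound in the set has produced a number, and no step between measured compounds can be drawn.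

Compound 4 `C=C1[C@@H](O)[C@]23C[C@@]1(O)CC[C@H]2[C@@]12C=C[C@H](O)[C@@](C)(C(=O)O1)[C@H]2[C@@H]3C(=O)OC` has not been measured. It differs from compound 1 by hydroxy in place of hydrogen on a saturated ring carbon. All shown values sit at the limit, (the limit of > 10000 nM in this assay, at which 3 of the 3 values shown sit), so the expected step that the limit leaves unreadable from compound 1 to compound 4 is none beyond the scatter. Compound 4 is thus expected to remain at or near the limit in this assay, with an estimate of 15000 nM and a range from 5000 nM to 50000 nM.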

Compound 4, half-maximal inhibitory concentration: > 10000 nM
Compound 4: a limit, no number; the forecaster's own chance of this, stated with the estimate: 85%; the middle value lies beyond the limit too.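

Compound 1 and compound 4 both stand at a limit in this assay and neither gives a number, so the step of hydroxy in place of hydrogen on a saturated ring carbon cannot be read. The compounds shown leave open whether any change to the shared core brings a number in this assay rather than a limit.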